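A few compounds are considered here, and "the series" means these few. Any claim that something is new, unique, unknown or untested is made for them only; others in the source may bear on it.

Values so far in a functional assay on a cell-free system (plasma, Homo sapiens), with a stated time of 3 min; on this read-out lower numbers stand for stronger inhibition and higher numbers for weaker inhibition

compound 1 `O=C(NCc1cc(Cl)ccc1-n1cnnn1)[C@@H]1C[C@@H]2C[C@@H]2N1C(=O)[C@H](O)CC1CC1` gives 1700 nM
compound 2 `CC1(C[C@@H](O)C(=O)N2N=CC[C@H]2C(=O)NCc2cc(Cl)ccc2-n2cnnn2)CC1` gives 730 nM
compound 3 `CC(C)(C)C[C@@H](O)C(=O)N1N=CC[C@H]1C(=O)NCc1cc(Cl)ccc1-n1cnnn1` gives 590 nM

Compound 3 and compound 2 lie within the scatter of each other, and compound 1 stands at a higher number than both. Compound 3 is the starting point for compound 4 `CC(C)(C)[C@@H](O)C(=O)N1N=CC[C@H]1C(=O)NCc1cc(Cl)ccc1-n1cnnn1` in this series. The change is tert-butyl in place of neopentyl on a saturated chain carbon bound to a carbonyl carbon and an oxygen on a saturated carbon with tert-butyl in place of neopentyl on a saturated chain carbon bound to a carbonyl carbon and an oxygen on a saturated carbon.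

Among the measured compounds shown here, only one measured step bears on this, and only in part. The step of a 1.2-fold lower number from compound 2 to compound 3 (0.09 log units; within the scatter) stays within the scatter. It puts tert-butyl in place of 1-methylcyclopropyl on a saturated chain carbon, two bonds along the chain from a carbonyl carbon and an oxygen on a saturated carbon, so it is not the change made here. For the measured compounds named here, compound 1 has a different core and offers no measured step. Going by the values given here, the data hold no direct precedent for replacing neopentyl with tert-butyl at this place, so the range stays wide.

In this assay a small move towards a higher number is expected, with no step beyond the scatter. The expected step is a 1.4-fold higher number from compound 3 to compound 4 (0.13 log units; within the scatter) as an estimate. For compound 4 the estimated value is 800 nM with an expected range from 250 nM to 2500 nM in this assay.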

Compound 4, half-maximal inhibitory concentration: 1400 nM
For compound 4 the middle estimate is 1.8-fold (0.24 log units) below the measured one; measured number inside the range.
By their numbers in this assay, from the lowest: compounds 3, 2, 4 and 1 (each within the scatter of the next, the first and the last beyond it).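

In this assay, putting tert-butyl in place of neopentyl on a saturated chain carbon bound to a carbonyl carbon and an oxygen on a saturated carbon gives a 2.4-fold higher number from compound 3 to compound 4 (0.38 log units; beyond the scatter) and so shows that this position does respond to the choice of group, whereas the earlier exchange, a 1.2-fold lower number from compound 2 to compound 3 (0.09 log units; within the scatter), showed no such response. The result is less clear against the other chain group, with a 1.9-fold higher number from compound 2 to compound 4 (0.28 log units; within the scatter), so tert-butyl stands clearly apart from neopentyl but not from (1-methylcyclopropyl)methyl. The data at hand offer no measured explanation for the step from neopentyl to tert-butyl.

Open, as far as these compounds go, is how the number moves at this position with a longer chain than neopentyl, with a cyclohexyl ring, or with a chain ending in an amine or a carboxylic acid. Also open, from the compounds shown here alone, is whether the exchange of neopentyl for tert-butyl would give a step of similar size on the core of compound 1, which carries a cyclopropylmethyl group and gives 1700 nM in this assay on that different core.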